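Swapping the thiophene for a pyridine on the amide side chain

The source may hold more compounds than are shown below. What is called first, only, known or untested is meant among the compounds shown, and "the series" means these compounds.

In an assay on HEK293 cells for agonist activity at transient receptor potential cation channel subfamily M member 8 (Homo sapiens), read by fluorescence and calcium flux, with a stated time of 15 min (a higher number here means that more compound is needed for the effect, a lower number that less compound is needed), compound 1 `CCN(Cc1ccco1)C(=O)COc1ccc(C)cc1` gives 489 nM, and compound 2 `CCN(Cc1ccsc1)C(=O)COc1ccc(C)cc1` gives 88 nM. Going by the values given here, compound 2 therefore has the lower of the two numbers measured so far, with the step of a 5.6-fold lower number from compound 1 to compound 2 (0.74 log units; beyond the scatter) lying beyond the scatter. Compound 3 `CCN(Cc1ccncc1)C(=O)COc1ccc(C)cc1` has not yet been measured in this assay. Compared with compound 2, it carries pyridin-4-yl in place of thiophen-3-yl on a saturated chain carbon bound to an amide-type nitrogen. Among the compounds with values here, the only measured step available, from compound 1 to compound 2, concerns a different pair of groups at the same place, so it does not speak directly to the present change; it shows only that exchanging one ring for another at this place can move the number well beyond the scatter, in either direction in principle. Within the data shown here, with no closer precedent, a cautious expectation is that compound 3 lies somewhat above compound 2, an estimated step of a 4.5-fold higher number from compound 2 to compound 3 (0.66 log units; beyond the scatter). On that basis compound 3 is expected to give about 400 nM in this assay, with a plausible range from 100 nM to 2000 nM.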

Compound 3, half-maximal effective concentration: "not active" (no number reported)
Compound 3 has no reported number here; there is nothing to compare the estimate with.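

In this assay, going by these compounds alone, compound 3 gives "not active" (no number reported), so no step from compound 2 to compound 3 can be read. Nothing at hand offers an explanation for this result. The compounds shown leave open how much more compound, if any concentration would do, the pyridin-4-yl group of compound 3 would need for the effect.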